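Trading a hydroxyphenyl for a methylphenyl on the shared core

The source may report more compounds than this note shows. Statements on the series, on what has been measured and on what is new or still open speak of the compounds shown alone.

In an ADME assay on Vero cells (Chlorocebus sabaeus) for cytotoxicity, read by neutral red uptake, tested at 25 ug/mL (on this read-out higher numbers stand for a weaker effect at the one concentration tested and lower numbers for a stronger effect), compound 1 `O=C1CSC(c2cccc(O)c2)N1CCN1CCCCC1` gives 100%. Compound 2 `COc1ccccc1C1SCC(=O)N1CCN1CCCCC1` gives 100% and compound 3 `O=C1CSC(c2ccccc2[N+](=O)[O-])N1CCN1CCCCC1` gives 100%, so compound 1 stands level with both at the digits shown. Among the measured compounds shown here, the only step among the measured compounds, no change at the digits printed from compound 2 to compound 3 (within the scatter), swaps one aromatic substituent for another and stays within the scatter. Compound 4 `Cc1ccc(C2SCC(=O)N2CCN2CCCCC2)cc1` differs from compound 1 on a saturated ring carbon of the shared core: 4-methylphenyl in place of 3-hydroxyphenyl on a saturated ring carbon. This exchange of one aryl group for another is only loosely matched by the measured step, yet all three aryl variants measured so far sit at the same reading. The step is therefore expected to be none beyond the scatter, no change at the digits printed from compound 1 to compound 4 (within the scatter). Compound 4 is estimated at 100%, between 85% and 100%.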

Compound 4, a percentage reported as activity, at one concentration (the size of the read-out at that concentration, not a potency): 100%
For compound 4 middle estimate and measured number coincide at the digits printed; measured number inside the range.
By their numbers in this assay, from the lowest: compounds 1, 2, 3 and 4 (each within the scatter of the next).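

In this assay the exchange on a saturated ring carbon of the shared core gives no change at the digits printed from compound 1 to compound 4 (within the scatter) and so shows that the reading holds when 3-hydroxyphenyl, with its hydrogen-bond donor and acceptor, gives way to 4-methylphenyl, which has neither. The earlier step was an exchange of methoxy for nitro on an aromatic carbon and involved no hydrogen-bond donor. No measurement at hand explains this result. The compounds shown leave open whether any group here would lower the reading, such as a carboxylic acid or an amine on the aromatic ring, or a longer alkyl chain in place of the aryl group.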